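The source may hold more compounds than are shown below. What is called first, only, known or untested is meant among the compounds shown, and "the series" means these compounds.

Measured compounds in a functional assay on Caco-2 cells (Homo sapiens) for activation, read by fluorescence, tested at 10 uM; on this read-out lower numbers stand for a stronger effect and higher numbers for a weaker effect at the one concentration tested:
- compound 1, `COCCNC(=C\C(=O)/C=C/c1ccc(O)cc1)/C=C/c1ccc(O)cc1`: compound 1 gives 89.7%
- compound 2, `COCCNC(=C\C(=O)/C=C/c1ccc(O)c(OC)c1)/C=C/c1ccc(O)c(OC)c1`: compound 2 gives 75.6%
- compound 3, `COCCCNC(=C\C(=O)/C=C/c1ccc(O)cc1)/C=C/c1ccc(O)cc1`: compound 3 gives 89%

Compound 1 and compound 3 differ only by methoxymethyl in place of methoxy on a saturated chain carbon, two bonds along the chain from an amine nitrogen. In this assay this made the step of a number 0.7 percentage points lower from compound 1 to compound 3 (within the scatter), so the two values are not distinguishable here. Compound 2 carries a different core; how the core of compound 2 differs from the core of compound 1 is not broken down here. Its value sits apart from the other two, beyond the scatter of both.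

Compound 4, `COCCCNC(=C\C(=O)/C=C/c1ccc(O)c(OC)c1)/C=C/c1ccc(O)c(OC)c1`, has not been measured. Going by the values given here, it differs from compound 2 by methoxymethyl in place of methoxy on a saturated chain carbon, two bonds along the chain from an amine nitrogen, the same change as the one from compound 1 to compound 3, at the same place. Among the compounds with values here, only that one pair carries the change among the measured compounds, so the expectation for compound 4 rests on it alone. In this assay the step from compound 2 to compound 4 is expected to be a number 0.6 percentage points lower from compound 2 to compound 4 (within the scatter), because of the step of a number 0.7 percentage points lower from compound 1 to compound 3 (within the scatter) on the other core. Compound 4 is therefore estimated at 75%, between 65% and 85%.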

Compound 4, a percentage reported as activity, at one concentration (the size of the read-out at that concentration, not a potency): 84.8%
Compound 4: middle estimate off by 9.8 percentage points, on the low side; measured number inside the range.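

In this assay, going by these compounds alone, the change from (2-methoxyethyl)amino to (3-methoxypropyl)amino gives a number 9.2 percentage points higher from compound 2 to compound 4 (within the scatter) and so cannot be told apart from no step on this core. The data do not show that the change is without effect on every core in the series, or that its size is identical on these two, as the comparison rests on a single pair of compounds per core and on one concentration. Within those limits, the change carries from one core to the other with no difference that can be resolved: the same change on two cores in this assay, a number 0.7 percentage points lower (within the scatter) from compound 1 to compound 3 and a number 9.2 percentage points higher (within the scatter) from compound 2 to compound 4, 9.9 percentage points apart, within the scatter of two such steps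

The compounds shown leave open whether the same holds for the amine side chain in other forms, such as a longer chain, a branched chain, or a chain with a hydroxyl or an amine in place of methoxy. They also leave open how the change behaves on cores whose aromatic rings carry groups such as fluoro or ethoxy.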